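This account rests on a few compounds, and the source may have more. Where it says the series, first, only, none or still open, it means among the compounds named here.

The measured compounds in a functional assay on MDA-MB-231 cells (Homo sapiens) for inhibition, read by sulforhodamine B assay, tested at 10 uM (on this read-out higher numbers stand for more inhibition at the one concentration tested (going by the name of the read-out) and lower numbers for less inhibition), are:

Compound 1, `CC(=O)N1N=C(c2ccc(N3CCN(C)CC3)cc2)CC1c1ccc(N(C)C)cc1`: -1%
Compound 2, `CC(=O)N1N=C(c2ccc(-n3cncn3)cc2)CC1c1ccc(N(C)C)cc1`: 7.4%
Compound 3, `CC(=O)N1N=C(c2ccc(-n3ccnc3)cc2)CC1c1ccc(N(C)C)cc1`: 5%

All three share the same core and differ only in the group on one aromatic carbon. On the numbers shown, compound 3 sits in the middle of the three, but its separation from its neighbours is small: a number 2.4 percentage points lower from compound 2 to compound 3 (within the scatter) and a number 6 percentage points higher from compound 1 to compound 3 (within the scatter) both fall within the scatter, as does a number 8.4 percentage points higher from compound 1 to compound 2 (within the scatter), so none of the three can be told apart in this assay.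

Compound 4, `COC(=O)CC(=O)N1N=C(c2ccc(-n3ccnc3)cc2)CC1c1ccc(N(C)C)cc1`, has not yet been measured. It differs from compound 3 at a place the measured steps never touch: methoxycarbonyl in place of hydrogen on a saturated chain carbon bound to a carbonyl carbon. For the measured compounds named here, the change sits on the acetyl rather than on the aromatic carbon, so no measured step bears on it directly. Going by the values given here, the only guide is that the three measured compounds all give numbers near zero in this assay regardless of the group on the aromatic carbon, and nothing in the data suggests the replacement on the acetyl should move the number beyond the scatter.

Compound 4 is therefore expected to give about 5% in this assay, in a range from -10% to 20%. The expected step of no change at the digits printed from compound 3 to compound 4 (within the scatter) is estimated to lie within the scatter.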

Compound 4, a percentage reported as inhibition, at one concentration (the size of the read-out at that concentration, not a potency): 2.3%
Estimate against measurement, compound 4: 2.7 percentage points above, and the stated range covers the measured number.
By their numbers in this assay, from the lowest: compounds 1, 4, 3 and 2 (each within the scatter of the next).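

In this assay, the change to methoxycarbonyl on a saturated chain carbon bound to a carbonyl carbon is the first shown at a place other than the aromatic carbon, and the result is a number 2.7 percentage points lower from compound 3 to compound 4 (within the scatter). This shows that turning the acetyl of compound 3 into the ((methoxycarbonyl)methyl)carbonyl of compound 4 leaves the two compounds indistinguishable in this assay, so this position, like the aromatic carbon, has so far given no step beyond the scatter, though it rests on a single change here. Nothing shown explains why the added group leaves the number within the scatter.

The compounds shown leave open whether a carboxylic acid in place of the methyl ester, an amine, or a longer chain on this same carbon would give a step beyond the scatter. Because every number shown comes from one concentration and lies close to the others, they also leave open whether the methoxycarbonyl group would have the same outcome when paired with the 1H-1,2,4-triazol-1-yl or 4-methylpiperazin-1-yl group on the aromatic carbon.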